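Acetyl in Place of Hydrogen on Two Related Cores

The compounds below may be only part of what the source reports. "The series", "measured", "known", "first", "only" and "open" are said of these compounds alone.

Four compounds share a linker ending in a dithiolane ring and an amide, joined through a triazole to an aromatic bicyclic core. They were tested in a functional assay on PC-12 cells (Rattus norvegicus) for cytotoxicity, read by MTT assay, with stated times of 3 h and 2 h, tested at 10 uM; on this read-out lower numbers stand for a weaker effect and higher numbers for a stronger effect at the one concentration tested. Compound 1 `O=C(CCCCC1CCSS1)NCc1cn(CCCOc2ccc3ccc(=O)oc3c2)nn1` gives 40% in this assay. Compound 2 `CC(=O)c1cc2ccc(OCCCn3cc(CNC(=O)CCCCC4CCSS4)nn3)cc2oc1=O` gives 38% in this assay. The change from compound 1 to compound 2 is acetyl in place of hydrogen on an aromatic carbon, and the step it made was a number 2 percentage points lower from compound 1 to compound 2 (within the scatter), so the two numbers cannot be told apart here.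

Compound 3 `O=C(CCCCC1CCSS1)NCc1cn(CCCCCOc2ccc3ccc(=O)oc3c2)nn1` carries a longer chain between the core and the triazole; the difference between the core of compound 1 and the core of compound 3 is not broken down here. In this assay compound 3 gives 71.3%, the highest of the three measured numbers, and its gap to compound 1 and to compound 2 lies beyond the usual scatter.

Compound 4 `CC(=O)c1cc2ccc(OCCCCCn3cc(CNC(=O)CCCCC4CCSS4)nn3)cc2oc1=O` has not yet been measured. It differs from compound 3 by acetyl in place of hydrogen on an aromatic carbon, the same change as that from compound 1 to compound 2, made at the same place. Because the earlier step was a number 2 percentage points lower from compound 1 to compound 2 (within the scatter), the step from compound 3 to compound 4 is expected to be small, about a number 2.3 percentage points lower from compound 3 to compound 4 (within the scatter). On that basis compound 4 is estimated at 69% in this assay, expected to fall between 56% and 82%.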

Compound 4, a percentage reported as activity, at one concentration (the size of the read-out at that concentration, not a potency): 20.8%
The estimate for compound 4 lay 48.2 percentage points above the measured number; the whole stated range lies above it.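

The same swap of acetyl for hydrogen on an aromatic carbon did not behave alike on the two cores in this assay, where it gave a number 50.5 percentage points lower from compound 3 to compound 4 (beyond the scatter). Set beside the earlier step, which could not be told from ordinary scatter, this shows that the effect of the change depends on the core that carries it, so a step measured on one core could not simply be added to the value of another in this series: the same change on two cores in this assay, a number 2 percentage points lower (within the scatter) from compound 1 to compound 2 and a number 50.5 percentage points lower (beyond the scatter) from compound 3 to compound 4, 48.5 percentage points apart, beyond the scatter of two such steps. Going by these compounds alone, it does not show why the two steps part, whether the longer chain of compound 3 alone accounts for the gap, or how the change would behave on any further core, since each core offers only one such pair and the result rests on just four compounds.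

Still open, from the compounds shown here alone, is whether the large step would also appear on a core with a chain longer than that of compound 3, or whether it is tied to this particular chain. Also open, going by these compounds, is how another group on the same aromatic carbon, such as a nitrile or a carboxylic acid, would behave on either core.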